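Working notes: aryl substituent exchange, compound 3 to compound 4

The source may report more compounds than this note shows. Statements on the series, on what has been measured and on what is new or still open speak of the compounds shown alone.

Compound 1 `O=C(Nc1cccc([N+](=O)[O-])c1)C1CCCN(C(=O)c2cc(C(F)(F)F)cc(C(F)(F)F)c2)C1`: in an ADME assay on PC-3 cells (Homo sapiens) for cytotoxicity, read by WST assay, tested at 100 uM (a higher number here means more inhibition at the concentration tested (going by the name of the read-out), a lower number less inhibition), compound 1 gives 9%.
Compound 2 `CSc1cccc(NC(=O)C2CCCN(C(=O)c3cc(C(F)(F)F)cc(C(F)(F)F)c3)C2)c1`: in this assay compound 2 gives 0%.
Compound 3 `O=C(Nc1cccc(CN2CCCC2)c1)C1CCCN(C(=O)c2cc(C(F)(F)F)cc(C(F)(F)F)c2)C1`: in this assay compound 3 gives 51%.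

Compound 3 stands highest of the three numbers. The two steps that reach it, a number 42 percentage points higher from compound 1 to compound 3 (beyond the scatter) and a number 51 percentage points higher from compound 2 to compound 3 (beyond the scatter), are both large, whereas a number 9 percentage points lower from compound 1 to compound 2 (within the scatter).

Compound 4 `COC(=O)c1cccc(NC(=O)C2CCCN(C(=O)c3cc(C(F)(F)F)cc(C(F)(F)F)c3)C2)c1` has not been measured. It differs from compound 3 in one place: methoxycarbonyl in place of (pyrrolidin-1-yl)methyl on an aromatic carbon. The place is on an aromatic carbon of a six-membered aromatic ring of carbon only, meta to a large group, the same position that is varied between compounds 1, 2 and 3.

Both measured steps touching compound 3 run toward it from a group other than (pyrrolidin-1-yl)methyl and are large rises; the two groups other than (pyrrolidin-1-yl)methyl at that position give values within the scatter of one another. Methoxycarbonyl has no direct precedent here, so the guidance is indirect. A large downward step is therefore expected in this assay: a number 41 percentage points lower from compound 3 to compound 4 (beyond the scatter). Compound 4 is expected to give about 10%, within a range from 0% to 30%.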

Compound 4, a percentage reported as inhibition, at one concentration (the size of the read-out at that concentration, not a potency): 0%
Compound 4: middle estimate off by 10 percentage points, on the high side; the measured number falls inside the stated range.
By their numbers in this assay, from the lowest: compounds 2, 4 and 1 (each within the scatter of the next); then compound 3.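

In this assay, methoxycarbonyl sits with nitro and methylsulfanyl at this position: the readings are (no change at the digits printed from compound 2 to compound 4 (within the scatter)) and (a number 9 percentage points lower from compound 1 to compound 4 (within the scatter)), so a third group without the (pyrrolidin-1-yl)methyl unit also fails to separate from the low set. The step (a number 51 percentage points lower from compound 3 to compound 4 (beyond the scatter)) is the third large step at this position, and all three run between (pyrrolidin-1-yl)methyl and another group. Among these four compounds, only compound 3 stands apart. No supporting data accompany these readings to account for the difference.

The compounds shown leave open whether the rise belongs to the pyrrolidine ring or to an amine at this place in general. An open-chain dimethylaminomethyl group or a piperidin-1-ylmethyl group would separate these readings, and a carboxylic acid in place of methoxycarbonyl would extend the low set.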